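Cytotoxicity limits in the series and the expected compound 4

This account rests on a few compounds, and the source may have more. Where it says the series, first, only, none or still open, it means among the compounds named here.

Compound 1 `O=C1Nc2ccccc2/C1=N/NC(=S)Nc1ccc(Br)cc1`, compound 2 `CCNC(=S)N/N=C1\C(=O)Nc2ccccc21` and compound 3 `O=C1Nc2ccccc2/C1=N/NC(=S)Nc1ccc(F)cc1` share one core and differ only at the amide-type nitrogen next to the thiocarbonyl carbon. In an ADME assay on RD cells (Homo sapiens) for cytotoxicity (on this read-out lower numbers stand for higher toxicity in this test and higher numbers for lower toxicity in this test), compound 1 gives > 25000 nM, a limit of the assay. Compound 2 gives > 25000 nM in this assay, again a limit. Compound 3 gives > 25000 nM in this assay, also a limit. The steps a step that the two limits leave unreadable from compound 1 to compound 2, a step that the two limits leave unreadable from compound 1 to compound 3 and a step that the two limits leave unreadable from compound 2 to compound 3 are therefore not readable in size; the evidence is the limit of > 25000 nM in this assay, at which 3 of the 3 values shown sit. Compound 3 thus stands only at a limit, as do the two other values.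

Compound 4 `O=C1Nc2ccccc2/C1=N/NC(=S)Nc1cccc(Cl)c1` differs from compound 3 by 3-chlorophenyl in place of 4-fluorophenyl on an amide-type nitrogen. Among the compounds with values here, the steps that bear on this change are the ones from compound 1 to compound 3 and from compound 2 to compound 3, both at the same nitrogen, both unreadable because of the limit of > 25000 nM in this assay, at which 3 of the 3 values shown sit. No step beyond the scatter is expected in this assay; compound 4 is expected to sit at the limit again. The estimate for compound 4 is 40000 nM, with a range from 20000 nM to 100000 nM, which means an expected step that the limit leaves unreadable from compound 3 to compound 4.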

Compound 4, half-maximal cytotoxic concentration: > 25000 nM
Compound 4: no number, only a limit; the forecaster's own chance of this, stated with the estimate: 80%; the middle value is on the limit's open side.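

In this assay, within the data shown here, compound 4 gives > 25000 nM as a limit of the assay, so no step from compound 1, compound 2 or compound 3 to compound 4 can be read in size: the limit of > 25000 nM in this assay, at which 4 of the 4 values shown sit.

The compounds shown leave open whether any group on the amide-type nitrogen shifts this read-out at all.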